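The source may report more compounds than this note shows. Statements on the series, on what has been measured and on what is new or still open speak of the compounds shown alone.

Two members of the series carry numbers in a functional assay on SNB-19 cells (Homo sapiens) for inhibition, read by sulforhodamine B assay, with a stated time of 48 h; a lower number here means a stronger inhibitor of growth, a higher number a weaker inhibitor of growth. Compound 1 `COc1cc2cc(Oc3ccc(NC(=O)Nc4cccc(C(F)(F)F)c4)cc3)c(C)nc2cc1OC` gives 15000 nM. Among the compounds with values here, compound 2 `COc1cc2cc(Oc3ccc(NC(=O)Nc4ccc(Cl)c(C(F)(F)F)c4)cc3)c(C)nc2cc1OC` gives 5310 nM, the lower of the two numbers; the single step in hand, a 2.8-fold lower number from compound 1 to compound 2 (0.45 log units; beyond the scatter), is modest but beyond the scatter. Compound 3 `COc1cc2cc(Oc3ccc(NC(=O)Nc4ccc(Cl)c(Cl)c4)cc3)c(C)nc2cc1OC` is the next case. Against compound 2 the difference is chloro in place of trifluoromethyl on an aromatic carbon. Within the data shown here, no measured step touches the trifluoromethyl itself: the one step available, a 2.8-fold lower number from compound 1 to compound 2 (0.45 log units; beyond the scatter), concerns the other chloro group, which compound 3 keeps, and it says nothing about exchanging trifluoromethyl for chloro on that ring. Among the measured compounds shown here, with no direct precedent, the working assumption is that the exchange leaves the number roughly where compound 2 sits. The expected step from compound 2 to compound 3 is therefore a 1.3-fold higher number from compound 2 to compound 3 (0.12 log units; within the scatter), not beyond the scatter. Compound 3 is estimated at 7000 nM, with a range from 3000 nM to 18000 nM.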

Compound 3, concentration for total growth inhibition: 24000 nM
Compound 3: the middle estimate sits 3.4-fold (0.54 log units) below what was measured; the measured number lies above the stated range.
By their numbers in this assay, from the lowest: compound 2; then compounds 1 and 3 (each within the scatter of the next).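

In this assay, trifluoromethyl and chloro are not interchangeable at this position when the other chloro group is kept: a 4.5-fold higher number from compound 2 to compound 3 (0.66 log units; beyond the scatter). The gain seen on adding chloro to the trifluoromethyl compound therefore does not belong to that chloro group alone, since a 1.6-fold higher number from compound 1 to compound 3 (0.20 log units; within the scatter), and among these three compounds only compound 2, with chloro and trifluoromethyl together, stands apart. No measurement shown here accounts for the loss on leaving trifluoromethyl.

Still open, as far as these compounds go, is how bromo, methyl or nitrile would read in place of trifluoromethyl, and thus whether compound 2 is unusual or compound 3 is. Also open, from the compounds shown here alone, is whether the same exchange would give a step of similar size on a ring without the other chloro group.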